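Aryl amide swap from compound 3 to compound 4

This account rests on a few compounds, and the source may have more. Where it says the series, first, only, none or still open, it means among the compounds named here.

Measured in a functional assay on NCI-H1299 cells (Homo sapiens) for inhibition, read by CCK-8 assay, with a stated time of 72 h, tested at 1 uM; on this read-out higher numbers stand for more inhibition of growth at the one concentration tested and lower numbers for less inhibition of growth:
compound 1 `CN(C)C(=O)c1cc2cnc(Nc3ccc(NC(=O)C4(C(=O)Nc5ccc(F)cc5)CC4)cc3)nc2n1C1CCCC1`: 93.3%
compound 2 `CN(C)C(=O)c1cc2cnc(Nc3ccc(NC(=O)C4(C(=O)Nc5ccccc5F)CC4)cc3)nc2n1C1CCCC1`: 70.2%
compound 3 `CN(C)C(=O)c1cc2cnc(Nc3ccc(NC(=O)C4(C(=O)Nc5cccc(Cl)c5)CC4)cc3)nc2n1C1CCCC1`: 47.9%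

Compound 3 stands lowest of the three in this assay, and its gaps to both others lie beyond the scatter. The next structure, compound 4 `CN(C)C(=O)c1cc2cnc(Nc3ccc(NC(=O)C4(C(=O)Nc5ccc(Cl)c(C(F)(F)F)c5)CC4)cc3)nc2n1C1CCCC1`, keeps the shared core and changes only the aryl group: 4-chloro-3-(trifluoromethyl)phenyl in place of 3-chlorophenyl on an amide-type nitrogen. In words, 4-chloro-3-(trifluoromethyl)phenyl replaces 3-chlorophenyl on an amide-type nitrogen.

All three measured steps concern this same place: a number 23.1 percentage points lower from compound 1 to compound 2 (beyond the scatter), a number 22.3 percentage points lower from compound 2 to compound 3 (beyond the scatter) and a number 45.4 percentage points lower from compound 1 to compound 3 (beyond the scatter). They show that this group alone can move the read-out substantially, so a step beyond the scatter is plausible. Going by the values given here, none of the measured compounds carries the entering group, however, and the data contain no direct precedent for it. The expected direction is upward, on thin support from a single compound: compound 1, at 93.3%, has a 4-fluorophenyl group, whose leading number is shared by the entering group. The expected step, of modest size and uncertain, is a number 17.1 percentage points higher from compound 3 to compound 4 (beyond the scatter). For compound 4 the estimated value is 65%, with an expected range of 40% to 90%.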

Compound 4, percent growth inhibition at one concentration: 39.5%
The estimate for compound 4 lay 25.5 percentage points above the measured number; the whole stated range lies above it.
By their numbers in this assay, from the lowest: compounds 4 and 3 (each within the scatter of the next); then compound 2; then compound 1.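

The swap gives a number 8.4 percentage points lower from compound 3 to compound 4 (within the scatter) in this assay, so 4-chloro-3-(trifluoromethyl)phenyl, with 11 heavy atoms against 7 for 3-chlorophenyl, cannot be told apart from 3-chlorophenyl at this amide-type nitrogen. Steps of a number 30.7 percentage points lower from compound 2 to compound 4 (beyond the scatter) and a number 53.8 percentage points lower from compound 1 to compound 4 (beyond the scatter) place compound 4 with compound 3 and well apart from both fluorophenyl compounds, and they show that a substituent named at the 4 position does not by itself carry over the read-out of compound 1. No measurement at hand explains why the groups at this place fall in this order.

As far as these compounds go, it stays open whether the read-out of compound 1 depends on fluorine itself, which 4-chlorophenyl, 3-fluorophenyl and unsubstituted phenyl would help to separate. From the compounds shown here alone, it also stays open whether a group of another kind on this nitrogen, such as a pyridyl ring, a methoxy-bearing phenyl or a phenyl carrying an amine, would hold the read-out of compound 1 or fall to the level of compound 3 and compound 4.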